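The source may report more compounds than this note shows. Statements on the series, on what has been measured and on what is new or still open speak of the compounds shown alone.

Measured so far:
Compound 1 `CCC(C(=O)N[C@@H](CC(=O)O)C(C)=O)n1cc(C(C)(C)C)nc(NCc2nonc2C)c1=O`: 5.12 nM
Compound 2 `CCCCCCN(C)CNCC(=O)[C@H](CC(=O)O)NC(=O)C(CC)n1cc(C(C)(CC)CC)nc(NCc2nonc2C)c1=O`: 0.025 nM

In a functional assay on NT2 cells (Homo sapiens) for inhibition (on this read-out higher numbers stand for weaker inhibition and lower numbers for stronger inhibition), compound 1 gives 5.12 nM, the higher of the two numbers and so the weaker inhibition. Compound 2 gives 0.025 nM, far lower and well beyond the scatter.

Compound 3 `CCC(C(=O)N[C@@H](CC(=O)O)C(=O)CNCN1CCCCC1)n1cc(C(C)(C)C)nc(NCc2nonc2C)c1=O` has not yet been measured. It keeps the core of compound 1 but carries ((piperidin-1-yl)methyl)amino in place of hydrogen on a saturated chain carbon bound to a carbonyl carbon. For the measured compounds named here, no measured pair isolates this change. Going by the values given here, the only guide is compound 2, which also carries a longer nitrogen-bearing chain there but differs from compound 1 elsewhere too. The value of compound 2, 0.025 nM, therefore suggests the direction of the change more than its size. A sizeable step in this assay towards stronger inhibition is expected, beyond the scatter but short of the full gap between the two measured compounds. The estimated change is a 13-fold lower number from compound 1 to compound 3 (1.11 log units; beyond the scatter). For compound 3 the expected value is 0.4 nM, with an estimated range of 0.06 nM to 3 nM.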

Compound 3, half-maximal inhibitory concentration: 0.29 nM
Estimate against measurement, compound 3: 1.4-fold (0.14 log units) above, within the range that was stated.
By their numbers in this assay, from the lowest: compound 2; then compound 3; then compound 1.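

In this assay, the saturated chain carbon bound to a carbonyl carbon now has a single measured change behind it: ((piperidin-1-yl)methyl)amino in place of hydrogen gives an 18-fold lower number from compound 1 to compound 3 (1.25 log units; beyond the scatter) and so shows that this position accepts a group of this size, with the number falling by a large step beyond the scatter. Compound 1 and compound 2 differ in more than one place, so they could only hint at what happens here, whereas this pair isolates the change with the rest of compound 1 left as it is. Nothing measured here gives a reason for the step.

The compounds shown leave open whether the piperidine ring itself matters, or whether a morpholine ring, a plain dimethylamino group or a hydroxyl group on the same carbon would give a similar step. They also leave open how much of the gap between compound 1 and compound 2 comes from the longer nitrogen-bearing chain at this position, and how much comes from the other places where the two differ.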